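Phenyl Substitution on a Fused Pyrazole Core: PC-3 Cytotoxicity

The source may hold more compounds than are shown below. What is called first, only, known or untested is meant among the compounds shown, and "the series" means these compounds.

Measured compounds:
compound 1 `CN1CCN(c2ccc(NC(=N)c3cc4cn[nH]c4cn3)cc2)CC1`: 45400 nM
compound 2 `CN1CCN(c2ccc(NC(=N)c3cc4cnn(C)c4cn3)cc2)CC1`: 32300 nM

In a functional assay on PC-3 cells (Homo sapiens) for cytotoxicity, read by MTT assay, with a stated time of 72 h (on this read-out higher numbers stand for weaker inhibition and lower numbers for stronger inhibition), compound 2 gives the lowest of the two numbers, and its nearest neighbour is compound 1, with a 1.4-fold lower number from compound 1 to compound 2 (0.15 log units; within the scatter). Compound 3 `CN1CCN(c2ccc(NC(=N)c3cc4c(-c5ccccc5)nn(C)c4cn3)cc2)CC1` differs from compound 2 by phenyl in place of hydrogen on an aromatic carbon. Going by the values given here, no measured step concerns a change of this kind; the only step recorded, from methyl in place of hydrogen on an aromatic nitrogen, stays within the scatter. For compound 3 a modest improvement is therefore estimated, a 1.6-fold lower number from compound 2 to compound 3 (0.21 log units; within the scatter), with wide uncertainty. The expected value for compound 3 is 20000 nM (range 5000 nM to 80000 nM).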

Compound 3, half-maximal inhibitory concentration: 5900 nM
Estimate against measurement, compound 3: 3.4-fold (0.53 log units) above, and the stated range covers the measured number.
By their numbers in this assay, from the lowest: compound 3; then compounds 2 and 1 (each within the scatter of the next).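

At this aromatic carbon of the five-membered ring, phenyl in place of hydrogen gives a 5.5-fold lower number from compound 2 to compound 3 (0.74 log units; beyond the scatter) in this assay. This position therefore responds to substitution, whereas the methyl on the ring nitrogen gave only a 1.4-fold lower number from compound 1 to compound 2 (0.15 log units; within the scatter). No available evidence accounts for the gain.

The compounds shown leave open whether a cyclohexyl ring, a pyridine ring, or a phenyl ring carrying an amine or a carboxylic acid would serve at this carbon. They also leave open whether phenyl has the same effect with hydrogen on the ring nitrogen.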